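Swapping the Aryl Group on the Three-Membered Ring

The source may report more compounds than this note shows. Statements on the series, on what has been measured and on what is new or still open speak of the compounds shown alone.

Compound 1 `CC[C@H](C)[C@H](N)CN(C(=O)[C@@H]1C[C@H]1c1ccc(OC)cc1)c1ccc(-c2ccccc2)cc1`: > 25000 nM, a limit of the assay
Compound 2 `CC[C@H](C)[C@H](N)CN(C(=O)[C@@H]1C[C@H]1c1cccc(OC)c1)c1ccc(-c2ccccc2)cc1`: 3000 nM
Compound 3 `CC[C@H](C)[C@H](N)CN(C(=O)[C@@H]1C[C@H]1c1cccc(C)c1)c1ccc(-c2ccccc2)cc1`: 1200 nM

In a functional assay for agonist activity at G protein-coupled receptor 88 (Homo sapiens), read by HTRF and cAMP accumulation (a lower number here means that less compound is needed, a higher number that more compound is needed for the effect), compound 3 stands lowest of the two numbers shown; the nearest is compound 2, with a 2.5-fold lower number from compound 2 to compound 3 (0.40 log units; beyond the scatter). Compound 1 sits at the limit of > 25000 nM in this assay, at which 1 of the 3 values shown sits. From that limit the steps are an at least 8.3-fold lower number from compound 1 to compound 2 (0.92 log units; beyond the scatter) and an at least 20-fold lower number from compound 1 to compound 3 (1.31 log units; beyond the scatter).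

Compound 4 `CC[C@H](C)[C@H](N)CN(C(=O)[C@@H]1C[C@H]1c1c(F)cccc1F)c1ccc(-c2ccccc2)cc1` differs from compound 3 by 2,6-difluorophenyl in place of 3-methylphenyl on a saturated ring carbon. All three measured steps change the same aryl group, and each moved the number markedly; yet none of them replaces the substituent pattern with a difluorinated one, so they bear on the new step only in showing that this position is sensitive. Given this, a step beyond the scatter in either direction is plausible, and a higher number is held somewhat more likely. Compound 4 is expected to give 3000 nM, with a range of 700 nM to 13000 nM. This estimate corresponds to an expected 2.5-fold higher number from compound 3 to compound 4 (0.40 log units; beyond the scatter).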

Compound 4, half-maximal effective concentration: 11000 nM
For compound 4 the middle estimate is 3.7-fold (0.56 log units) below the measured one; the range from low to high includes it.
By their numbers in this assay, from the lowest: compound 3; then compound 2; then compound 4. At a limit, above all of these: compound 1.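

With 2,6-difluorophenyl on the saturated ring carbon, the earlier single-substituent aryl groups give way to one carrying two fluorines, and in this assay this costs much of what 3-methylphenyl had reached, with a 9.2-fold higher number from compound 3 to compound 4 (0.96 log units; beyond the scatter), and also falls short of 3-methoxyphenyl, with a 3.7-fold higher number from compound 2 to compound 4 (0.56 log units; beyond the scatter). Even so, the difluorinated group gives a measurable value and stays ahead of 4-methoxyphenyl, with an at least 2.2-fold lower number from compound 1 to compound 4 (0.35 log units; beyond the scatter). Compound 1 stands at a limit and not at a number, so that last step has only a lower bound: the limit of > 25000 nM in this assay, at which 1 of the 4 values shown sits.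

On these data alone, what a single fluorine or a 2,6-dimethylphenyl group would do at this position stays open, so the step to compound 4 cannot be divided between the identity of the substituents and their placement. As far as these compounds go, the effect of an unsubstituted phenyl or a pyridine ring here also remains unknown.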